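The compounds below may be only part of what the source reports. "The series", "measured", "known", "first", "only" and "open" are said of these compounds alone.

Compound 1 `O=[N+]([O-])c1ccc(-c2nnc(SCCCN3CCN(c4nc5ccccc5o4)CC3)o2)cc1`: 90100 nM
Compound 2 `Oc1ccc(-c2nnc(SCCCN3CCN(c4nc5ccccc5o4)CC3)o2)cc1`: 260000 nM

Both were tested in a functional assay on MCF7 cells (Homo sapiens) for inhibition, read by MTT assay, with a stated time of 72 h; a lower number here means a stronger inhibitor, a higher number a weaker inhibitor. Compound 1 holds the lower of the two numbers, and the gap to compound 2 is a 2.9-fold higher number from compound 1 to compound 2 (0.46 log units; beyond the scatter). Compound 3 `O=C(NCc1nnc(SCCCN2CCN(c3nc4ccccc4o3)CC2)o1)c1ccccc1` has not been measured; it differs from compound 1 in one place: benzamidomethyl in place of 4-nitrophenyl on an aromatic carbon. Among the compounds with values here, the only measured step that speaks to this change is the one from compound 1 to compound 2, where replacing the nitro group moved the number modestly upward. Within the data shown here, the change to compound 3 is a larger one, exchanging the whole 4-nitrophenyl group for benzamidomethyl, and there is no measured step for that exact exchange. A modest rise of similar size is therefore expected, with wide uncertainty: compound 3 is estimated at 160000 nM in this assay, with a range from 45000 nM to 500000 nM, meaning an expected step of a 1.8-fold higher number from compound 1 to compound 3 (0.25 log units; within the scatter).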

Compound 3, half-maximal inhibitory concentration: 52700 nM
Compound 3: the middle estimate sits 3.0-fold (0.48 log units) above what was measured; measured number inside the range.
By their numbers in this assay, from the lowest: compounds 3 and 1 (each within the scatter of the next); then compound 2.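

In this assay, the aromatic carbon of the five-membered ring accepts an exchange of the whole 4-nitrophenyl group for benzamidomethyl, and the two compounds stay within the usual scatter of each other (a 1.7-fold lower number from compound 1 to compound 3 (0.23 log units; within the scatter)). The same benzamidomethyl group does separate from the 4-hydroxyphenyl group (a 4.9-fold lower number from compound 2 to compound 3 (0.69 log units; beyond the scatter)), so among these three compounds, compound 2 is the one that stands apart. Nothing available explains either step.

The compounds shown leave open which part of benzamidomethyl carries the result, the amide or its benzene ring, since the two always appear together here. A simple amine, a carboxylic acid or a longer chain in the same place would show whether this position stays as accepting with groups of other kinds.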